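Trifluoromethyl gives way to methyl on an aromatic ring

The compounds below may be only part of what the source reports. "The series", "measured", "known", "first", "only" and "open" are said of these compounds alone.

In a functional assay on MCF7 cells (Homo sapiens) for antiproliferative activity, read by MTT assay, with a stated time of 72 h (on this read-out lower numbers stand for stronger inhibition and higher numbers for weaker inhibition), compound 1 `O=S(=O)(Oc1ccccc1)C1CC2OC1C(c1ccc(/C=C/c3cc(O)cc(O)c3)cc1)=C2c1ccc(O)cc1` gives 20100 nM. Compound 2 `Cc1ccccc1OS(=O)(=O)C1CC2OC1C(c1ccc(/C=C/c3cc(O)cc(O)c3)cc1)=C2c1ccc(O)cc1` gives 55800 nM, and compound 3 `O=S(=O)(Oc1cccc(C(F)(F)F)c1)C1CC2OC1C(c1ccc(/C=C/c3cc(O)cc(O)c3)cc1)=C2c1ccc(O)cc1` gives 11500 nM. Compound 3 cannot be separated from compound 1, given a 1.7-fold lower number from compound 1 to compound 3 (0.24 log units; within the scatter), but it stands clear of compound 2, given a 4.9-fold lower number from compound 2 to compound 3 (0.69 log units; beyond the scatter).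

Compound 4 `Cc1cccc(OS(=O)(=O)C2CC3OC2C(c2ccc(/C=C/c4cc(O)cc(O)c4)cc2)=C3c2ccc(O)cc2)c1` carries methyl in place of trifluoromethyl on an aromatic carbon, meta to a large group: methyl in place of trifluoromethyl on an aromatic carbon. Among the measured compounds shown here, no measured step makes this exchange directly, so the evidence is indirect. Compound 3 shows that trifluoromethyl in place of hydrogen moved the number only within the scatter, as the step from compound 1 already shows. For the measured compounds named here, the 2-methylphenyl of compound 2 offers the only methyl example, with a 2.8-fold higher number from compound 1 to compound 2 (0.44 log units; beyond the scatter), though the 3-methylphenyl of compound 4 is not the same group. Compound 4 is therefore expected to lie near compound 1 or a little higher. The expected change is a 2.1-fold higher number from compound 3 to compound 4 (0.32 log units; beyond the scatter), a modest step upward. For compound 4 the estimate is 24000 nM, with an expected range of 11000 nM to 50000 nM.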

Compound 4, half-maximal inhibitory concentration: 16300 nM
For compound 4 the middle estimate is 1.5-fold (0.17 log units) above the measured one; the range from low to high includes it.
By their numbers in this assay, from the lowest: compounds 3, 4 and 1 (each within the scatter of the next); then compound 2.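

Compound 4 supplies the direct comparison of methyl and trifluoromethyl on this aromatic carbon, meta to a large group, and in this assay the two groups cannot be separated (a 1.4-fold higher number from compound 3 to compound 4 (0.15 log units; within the scatter)), nor can methyl there be separated from hydrogen (a 1.2-fold lower number from compound 1 to compound 4 (0.09 log units; within the scatter)). The earlier methyl example was the 2-methylphenyl of compound 2, and the exchange for 3-methylphenyl gives a clear difference (a 3.4-fold lower number from compound 2 to compound 4 (0.53 log units; beyond the scatter)), so the high number of compound 2 does not carry over to a methyl at this position. Nothing measured here explains these numbers.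

The compounds shown leave open whether an amine, a carboxylic acid or a longer chain on this carbon would move the number beyond the scatter. They also leave open whether trifluoromethyl would show the same difference between these two ring positions that methyl shows.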